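This account rests on a few compounds, and the source may have more. Where it says the series, first, only, none or still open, it means among the compounds named here.

Compound 1 `CC1=CSC2=NC(/C=C/c3ccccc3Cl)=C(C(=O)/C=C/c3ccccc3Cl)C(c3ccccc3)N12` gives 206 ug/mL in an ADME assay on Vero cells (Chlorocebus sabaeus) for cytotoxicity, read by fluorescence and resazurin assay, with a stated time of 72 h; a higher number here means that more compound is tolerated, a lower number that less compound is tolerated. Compound 2 `COc1cc(/C=C\C2=C(C(=O)/C=C/c3cc(OC)c(OC)c(OC)c3)C(c3cc(OC)c(OC)c(OC)c3)N3C(C)=CSC3=N2)cc(OC)c1OC` gives 167 ug/mL in this assay, and the two figures lie within the scatter of each other, so no order between them can be read. Compound 3 `CC1=CSC2=NC(/C=C/c3ccccc3Cl)=C(C(=O)/C=C/c3ccccc3Cl)C(c3ccc(Cl)cc3)N12` differs from compound 1 by chloro in place of hydrogen on an aromatic carbon. For the measured compounds named here, no step between measured compounds isolates such a change here, so nothing beyond the scatter is expected in this assay, and the step of a 1.1-fold lower number from compound 1 to compound 3 (0.06 log units; within the scatter) is estimated as essentially flat. Compound 3 is expected to give 180 ug/mL, with a range from 100 ug/mL to 320 ug/mL.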

Compound 3, half-maximal cytotoxic concentration: 430 ug/mL
Compound 3: the middle estimate sits 2.4-fold (0.38 log units) below what was measured; measured number above the stated range.
By their numbers in this assay, from the lowest: compounds 2 and 1 (each within the scatter of the next); then compound 3.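

In this assay, phenyl to 4-chlorophenyl gives a 2.1-fold higher number from compound 1 to compound 3 (0.32 log units; beyond the scatter), so more compound is tolerated with chloro at this place, para to a large group. For the compounds shown here, this is the first step that isolates a single change, and it is modest. Nothing available explains the step.

Going by these compounds, whether an amine, a methoxy group or a carboxylic acid at this place would shift the number the same way stays open. So does whether chloro elsewhere on this ring would do so.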